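Removing a carbonyl from the side chain of the core

A few compounds are considered here, and "the series" means these few. Any claim that something is new, unique, unknown or untested is made for them only; others in the source may bear on it.

Of the compounds shown here, two built on one shared core have been measured. Compound 1 `Cc1nn(-c2ncnc3nc[nH]c23)c2c1C(OCC(=O)c1ccc(F)cc1)CC(=O)N2` gives 973 nM in a functional assay on HEK293 cells for agonist activity at G-protein coupled receptor 39 (Homo sapiens), read by scintillation proximity assay and inositol phosphate accumulation, with a stated time of 75 min (a lower number here means that less compound is needed, a higher number that more compound is needed for the effect), and compound 2 `Cc1nn(-c2ncnc3nc[nH]c23)c2c1C(OCc1ccc(F)cc1)CC(=O)N2` gives 126 nM. Within the data shown here, compound 1 thus has the highest number of the two, and the only step available, a 7.7-fold lower number from compound 1 to compound 2 (0.89 log units; beyond the scatter), leads to its nearest neighbour. Compound 3 `COc1ccc(CCOC2CC(=O)Nc3c2c(C)nn3-c2ncnc3nc[nH]c23)cc1` has not yet been measured. It differs from compound 1 in one place: 4-methoxybenzyl in place of (4-fluorophenyl)carbonyl on a saturated chain carbon bound to an oxygen on a saturated carbon. Among the measured compounds shown here, the one measured step that bears on this change, a 7.7-fold lower number from compound 1 to compound 2 (0.89 log units; beyond the scatter), also removed the carbonyl from the side chain and was modest in size but clearly beyond the scatter. The exchange of a fluorine for a methoxy group on the ring has no measured counterpart among these compounds, so it remains an unknown. On that basis compound 3 is expected to give a lower number, by a step of about a 6.1-fold lower number from compound 1 to compound 3 (0.78 log units; beyond the scatter). The estimate for compound 3 in this assay is 160 nM, with a plausible range from 50 nM to 500 nM.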

Compound 3, half-maximal effective concentration: 70 nM
The estimate for compound 3 lay 2.3-fold (0.36 log units) above the measured number; low and high end bracket the measured number.
By their numbers in this assay, from the lowest: compounds 3 and 2 (each within the scatter of the next); then compound 1.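

The 2-(4-methoxyphenyl)ethyl chain also lacks the carbonyl, and putting it in place of the ((4-fluorophenyl)carbonyl)methyl chain gives a 14-fold lower number from compound 1 to compound 3 (1.14 log units; beyond the scatter) in this assay, so a second carbonyl-free chain at this position also lies well under compound 1. Exchanging 4-fluorophenyl for 4-methoxybenzyl gives a 1.8-fold lower number from compound 2 to compound 3 (0.26 log units; within the scatter) and so does not separate these two compounds, although this single exchange alters both the chain and the ring substituent, and the two alterations cannot be judged apart. No measured evidence is available to explain these results.

A 4-fluorobenzyl or a 4-methoxyphenyl group at this place would show what each alteration does alone. From the compounds shown here alone, whether the aromatic ring is needed at all stays open, and an amine or a carboxylic acid at the chain end would test this.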